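Ethoxycarbonyl in Place of 2-Fluorophenyl: an Expected Cytotoxicity Step

This account rests on a few compounds, and the source may have more. Where it says the series, first, only, none or still open, it means among the compounds named here.

Among the compounds with values here, compound 3 `COc1nc2ccc(Br)cc2cc1C(c1ccccc1)n1cc(-c2ccccc2F)nn1` is one of three compounds measured in an ADME assay on PANC-1 cells (Homo sapiens) for cytotoxicity, read by sulforhodamine B assay, with a stated time of 48 h, tested at 10 uM (on this read-out lower numbers stand for less inhibition and higher numbers for more inhibition at the one concentration tested (going by the name of the read-out)), where compound 3 gives 14.7%. This is the highest of the three numbers, but compound 1 `COc1nc2ccc(Br)cc2cc1C(c1ccccc1)n1cc(-c2ccc(Br)cc2)nn1` gives 10.4% and compound 2 `CCCCCCc1cn(C(c2ccccc2)c2cc3cc(Br)ccc3nc2OC)nn1` gives 6.08%, and both steps, a number 4.3 percentage points higher from compound 1 to compound 3 (within the scatter) and a number 8.6 percentage points higher from compound 2 to compound 3 (within the scatter), lie within the scatter, so no order among them can be claimed. Compound 4 `CCOC(=O)c1cn(C(c2ccccc2)c2cc3cc(Br)ccc3nc2OC)nn1` differs from compound 3 in one place: ethoxycarbonyl in place of 2-fluorophenyl on an aromatic carbon. The step most like it is a number 4.3 percentage points lower from compound 1 to compound 2 (within the scatter), where a chain replaced an aryl group at the same place; together with a number 4.3 percentage points higher from compound 1 to compound 3 (within the scatter) it shows changes there staying within the scatter. The expected step is therefore a number 5.7 percentage points lower from compound 3 to compound 4 (within the scatter), nothing beyond the scatter. Compound 4 is estimated at 9%, between 0% and 20%.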

Compound 4, a percentage reported as inhibition, at one concentration (the size of the read-out at that concentration, not a potency): 15.4%
Beside the measured number, compound 4's estimate is 6.4 percentage points below it; the measured number falls inside the stated range.
By their numbers in this assay, from the lowest: compounds 2, 1, 3 and 4 (each within the scatter of the next).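

In this assay, ethoxycarbonyl brings hydrogen-bond acceptors to this aromatic carbon where 2-fluorophenyl has none, yet the steps stay within the scatter: a number 0.7 percentage points higher from compound 3 to compound 4 (within the scatter), a number 5 percentage points higher from compound 1 to compound 4 (within the scatter) and a number 9.3 percentage points higher from compound 2 to compound 4 (within the scatter). The four groups at this place, two aryl groups, a hexyl chain and ethoxycarbonyl, therefore cannot be put in any order. No measurement shown here bears on the result.

As far as these compounds go, it remains open whether a group such as an amine or a carboxylic acid at this place would give a step beyond the scatter.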